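This account rests on a few compounds, and the source may have more. Where it says the series, first, only, none or still open, it means among the compounds named here.

Compound 2 `C/C=C/C(=O)Nc1c(C(O)(C(F)(F)F)C(F)(F)F)ccc2ccccc12` gives 72 nM in an assay on LtK cells with ATP-sensitive inward rectifier potassium channel 11 (Homo sapiens) as the target (on this read-out lower numbers stand for an effect already at smaller amounts and higher numbers for an effect only at larger amounts of compound), the highest of the three numbers at hand. Compound 1 `CCC(=O)Nc1c(C(O)(C(F)(F)F)C(F)(F)F)ccc2ccccc12` gives 15 nM, and compound 3 `O=C(Nc1c(C(O)(C(F)(F)F)C(F)(F)F)ccc2ccccc12)C1CCC1` gives 45 nM. The steps of a 4.8-fold higher number from compound 1 to compound 2 (0.68 log units; beyond the scatter) and a 3.0-fold higher number from compound 1 to compound 3 (0.48 log units; beyond the scatter) both move to higher numbers when ethyl on the carbonyl carbon is exchanged, while a 1.6-fold lower number from compound 2 to compound 3 (0.20 log units; within the scatter) lies within the scatter. Compound 4 `O=C(Nc1c(C(O)(C(F)(F)F)C(F)(F)F)ccc2ccccc12)c1ccccc1` differs from compound 2 in one place: phenyl in place of prop-1-en-1-yl on a carbonyl carbon. The two measured steps away from ethyl bear on this change, yet neither of them enters a phenyl, so only a modest further rise, or none beyond the scatter, is expected. Compound 4 is therefore estimated to give about 100 nM, between 30 nM and 350 nM, which means an expected step of a 1.4-fold higher number from compound 2 to compound 4 (0.14 log units; within the scatter).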

Compound 4, half-maximal effective concentration: 44 nM
Beside the measured number, compound 4's estimate is 2.3-fold (0.36 log units) above it; measured number inside the range.
By their numbers in this assay, from the lowest: compound 1; then compounds 4, 3 and 2 (each within the scatter of the next).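

Phenyl, the only aromatic ring among these groups on the carbonyl carbon, also moves away from ethyl (a 2.9-fold higher number from compound 1 to compound 4 (0.47 log units; beyond the scatter)). It cannot be told apart from the other two replacements (a 1.6-fold lower number from compound 2 to compound 4 (0.21 log units; within the scatter); a 1.0-fold lower number from compound 3 to compound 4 (0.01 log units; within the scatter)), so in this assay ethyl in compound 1 alone stands apart, with the lowest number. Nothing at hand explains these numbers.

Going by these compounds, it remains open whether methyl, a longer chain or a phenyl carrying an amine or a carboxylic acid would fall below compound 1 or rise above compound 2. On these data alone, whether any change elsewhere on the shared core would alter these steps also remains open.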